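A few compounds are considered here, and "the series" means these few. Any claim that something is new, unique, unknown or untested is made for them only; others in the source may bear on it.

Measured compounds, with their percentages in a functional assay on PC-3 cells (Homo sapiens) for antiproliferative activity, read by MTT assay, tested at 5 uM; a lower number here means a weaker effect, a higher number a stronger effect of the compound at the concentration tested:

compound 1, `COc1cc(C(=O)N/N=C/c2ccc(F)c(F)c2)cc(OC)c1OC`, gives 43.7%
compound 2, `COc1cc(C2=NN(C(C)=O)C(c3c(Cl)cccc3Cl)O2)cc(OC)c1OC`, gives -2.2%
compound 3, `COc1cc(C2=NN(C(C)=O)C(c3cc(OC)c(OC)c(OC)c3)O2)cc(OC)c1OC`, gives 0.1%

Among these three numbers compound 2 stands lowest. Its nearest neighbour is compound 3, whose value lies within the usual scatter of this kind of measurement, so the two cannot be told apart. Its furthest neighbour is compound 1, whose value lies well beyond the scatter, so compound 1 clearly does more in this assay than compound 2.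

Compound 4, `COc1cc(C2=NN(C(C)=O)C(c3ccccc3C(F)(F)F)O2)cc(OC)c1OC`, has not yet been measured. It differs from compound 2 in one place: 2-(trifluoromethyl)phenyl in place of 2,6-dichlorophenyl on a saturated ring carbon. The rest of the shared core, including the acetyl group on the ring nitrogen and the trimethoxyphenyl attached to the five-membered non-aromatic ring, is unchanged.

For the measured compounds named here, no step between two measured compounds is available to guide the guess. Compound 2 and compound 3 both sit near zero despite carrying quite different groups on the same saturated ring carbon, which suggests that this position tolerates change without a large rise. The expected step from compound 2 to compound 4 is therefore small, a number 7.2 percentage points higher from compound 2 to compound 4 (within the scatter), at most a modest upward move. Compound 4 is expected to give about 5%, within a range from -10% to 25%.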

Compound 4, a percentage reported as inhibition, at one concentration (the size of the read-out at that concentration, not a potency): 15.2%
Beside the measured number, compound 4's estimate is 10.2 percentage points below it; low and high end bracket the measured number.
By their numbers in this assay, from the lowest: compounds 2 and 3 (each within the scatter of the next); then compound 4; then compound 1.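

In this assay, a single change on the saturated ring carbon moves the read-out by more than the usual scatter: 2-(trifluoromethyl)phenyl in place of 2,6-dichlorophenyl gives a number 17.4 percentage points higher from compound 2 to compound 4 (beyond the scatter). For the compounds shown here, the earlier compounds offered no such one-place step, so this is the first sign that the aromatic group at this carbon can shift the number while the acetyl group and the trimethoxyphenyl stay the same, though the step is only modest. Nothing at hand bears on why the number rises.

The compounds shown leave open whether the rise comes from the trifluoromethyl group itself or from having one group rather than two chlorines on the phenyl ring, a question that a plain phenyl at this carbon would help to settle. Also open, on these data alone, is what a quite different group would do here, such as a pyridine ring or a phenyl ring carrying a carboxylic acid, and whether the acetyl group on the ring nitrogen could give way to a longer chain such as butanoyl.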